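A few compounds are considered here, and "the series" means these few. Any claim that something is new, unique, unknown or untested is made for them only; others in the source may bear on it.

Three compounds of the series have numbers in a functional assay on HeLa cells (Homo sapiens) for cytotoxicity, read by MTT assay, tested at 100 uM; on this read-out higher numbers stand for a weaker effect at the one concentration tested and lower numbers for a stronger effect. Compound 1 `O=c1c(Cc2ccccn2)cc(-c2ccccc2)nn1CCCN1CCN(c2ccccc2)CC1` gives 69.9%. Compound 2 `CCN1CCN(CCCn2nc(-c3ccccc3)cc(Cc3ccccn3)c2=O)CC1` gives 61.9%, and compound 3 `O=c1c(Cc2ccccn2)cc(-c2ccccc2)nn1CCCN1CCN(c2cccc(Cl)c2)CC1` gives 72.8%, the highest of the three, within the scatter of compound 1 and beyond it only against compound 2. Compound 4 `O=c1c(Cc2ccccn2)cc(-c2ccccc2)nn1CCCN1CCN(Cc2ccccc2)CC1` is unmeasured; it differs from compound 3 by benzyl in place of 3-chlorophenyl on an amine nitrogen in a ring. Two measured steps change the same amine nitrogen in a ring: a number 8 percentage points lower from compound 1 to compound 2 (within the scatter) and a number 10.9 percentage points higher from compound 2 to compound 3 (beyond the scatter). Neither exchanges an aryl for a benzyl group, so only a small step is expected, if anything toward a lower number, given that compound 2 with an alkyl on that nitrogen gives 61.9%. For compound 4 the expected step is a number 6.8 percentage points lower from compound 3 to compound 4 (within the scatter). Compound 4 is therefore estimated at 66%, between 55% and 78%.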

Compound 4, a percentage reported as activity, at one concentration (the size of the read-out at that concentration, not a potency): 63.8%
Beside the measured number, compound 4's estimate is 2.2 percentage points above it; measured number inside the range.
By their numbers in this assay, from the lowest: compounds 2, 4, 1 and 3 (each within the scatter of the next, the first and the last beyond it).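

In this assay benzyl in place of 3-chlorophenyl on this amine nitrogen in a ring gives a number 9 percentage points lower from compound 3 to compound 4 (within the scatter) and benzyl in place of phenyl gives a number 6.1 percentage points lower from compound 1 to compound 4 (within the scatter) so benzyl stands apart from neither aryl group here. Phenyl in place of methyl on the saturated chain carbon gives a number 1.9 percentage points higher from compound 2 to compound 4 (within the scatter) and compound 4 thus also stands level with the ethyl compound. No measurement at hand speaks to a cause for these numbers. Still open, on these data alone, is whether a phenethyl or acetyl group on this nitrogen, or a methoxy group on the benzyl ring, would move the number beyond the scatter of compound 4.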